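Ring Contraction at the Distal Hydroxylated Amine

The source may hold more compounds than are shown below. What is called first, only, known or untested is meant among the compounds shown, and "the series" means these compounds.

Compound 1 `O=C1CCC(CCN2CC(N3CCNCC3)C2)(c2ccc(Cl)c(Cl)c2)CN1Cc1ccccc1` — 5.01 nM
Compound 2 `CC(=O)N1CCN(C2CN(CCC3(c4ccc(Cl)c(Cl)c4)CCC(=O)N(Cc4ccccc4)C3)C2)CC1` — 1.59 nM
Compound 3 `O=C1CCC(CCN2CC(N3CCC(O)CC3)C2)(c2ccc(Cl)c(Cl)c2)CN1Cc1ccccc1` — 0.0794 nM

All three compounds were tested in an assay on isolated protein (artery, Oryctolagus cuniculus) with Substance-P receptor (Homo sapiens) as the target; on this read-out higher numbers stand for weaker binding and lower numbers for tighter binding. Compound 3 gives the lowest number of the three, and so binds most tightly: the step from compound 2 to compound 3 is a 20-fold lower number from compound 2 to compound 3 (1.30 log units; beyond the scatter), and the step from compound 1 to compound 3 is a 63-fold lower number from compound 1 to compound 3 (1.80 log units; beyond the scatter). The smaller step of a 3.2-fold lower number from compound 1 to compound 2 (0.50 log units; beyond the scatter) shows that even a change on the distant nitrogen of the piperazine ring is felt.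

Compound 4 `O=C1CCC(CCN2CC(N3CCC(O)C3)C2)(c2ccc(Cl)c(Cl)c2)CN1Cc1ccccc1` has not yet been measured. It differs from compound 3 in one place: 3-hydroxypyrrolidin-1-yl in place of 4-hydroxypiperidin-1-yl on a saturated ring carbon.

Within the data shown here, none of the measured steps changes a ring size at this position; each replaces the whole outer ring or decorates its nitrogen. What they do show is that this assay responds strongly to what sits on that saturated ring carbon, with the hydroxy-bearing ring of compound 3 clearly ahead of both piperazine variants. Shrinking that ring by one carbon keeps the hydroxyl but moves it; a modest loss is expected, with the step from compound 3 to compound 4 estimated at a 3.8-fold higher number from compound 3 to compound 4 (0.58 log units; beyond the scatter). Compound 4 is therefore estimated at 0.3 nM, within a range of 0.06 nM to 1.5 nM.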

Compound 4, dissociation constant: 2 nM
Beside the measured number, compound 4's estimate is 6.7-fold (0.82 log units) below it; measured number above the stated range.
By their numbers in this assay, from the lowest: compound 3; then compounds 2 and 4 (each within the scatter of the next); then compound 1.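

In this assay, taking 4-hydroxypiperidin-1-yl out and putting 3-hydroxypyrrolidin-1-yl in on the four-membered ring gives a 25-fold higher number from compound 3 to compound 4 (1.40 log units; beyond the scatter), so a small edit to the outer ring matters here even though a hydroxyl and the ring nitrogen both remain. The advantage of compound 3 therefore does not extend to this other hydroxy-bearing ring: a 1.3-fold higher number from compound 2 to compound 4 (0.10 log units; within the scatter) leaves compound 4 within the scatter of the acetylated piperazine, and a 2.5-fold lower number from compound 1 to compound 4 (0.40 log units; beyond the scatter) puts it only modestly ahead of the plain piperazine. The data offer no measurement that explains the size of this loss.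

Ring size and the place of the hydroxyl change together in this step, so the compounds shown cannot separate the two, whereas 3-hydroxypiperidin-1-yl would keep the six-membered ring and change only where the hydroxyl sits. Going by these compounds, whether the hydroxyl itself is needed also stays open, and plain piperidin-1-yl, which has the same ring as compound 3 without the hydroxyl, would be the direct comparison.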